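Extending the methyl of compound 3 to ethyl

The compounds below may be only part of what the source reports. "The series", "measured", "known", "first", "only" and "open" are said of these compounds alone.

In a functional assay on NCI/ADR-RES cells (Homo sapiens) for inhibition, read by sulforhodamine B assay, with a stated time of 48 h (on this read-out lower numbers stand for stronger inhibition of growth and higher numbers for weaker inhibition of growth), compound 1 (`S=C(N/N=C/c1cccs1)Nc1ccccc1`) gives > 100000 nM, which is a limit of the assay and not a number. Compound 2 (`S=C(N/N=C/c1cccs1)Nc1cccc2ccccc12`) gives 6600 nM and compound 3 (`Cc1ccc(NC(=S)N/N=C/c2cccs2)cc1`) gives 4800 nM, two values that lie within the scatter of each other.

Compound 4 (`CCc1ccc(NC(=S)N/N=C/c2cccs2)cc1`) differs from compound 3 by methyl in place of hydrogen on a saturated chain carbon bound to an aromatic carbon, which is methyl in place of hydrogen on a saturated chain carbon bound to an aromatic carbon, or methyl to ethyl. Going by the values given here, only one measured step bears on this change: an at least 20-fold lower number from compound 1 to compound 3 (1.31 log units; beyond the scatter), a large step that placed methyl on an aromatic carbon. That step starts from a limit, and it acts at a different place, so its size is not carried over here. No step beyond the scatter is expected in this assay, and the estimated step is a 1.1-fold lower number from compound 3 to compound 4 (0.03 log units; within the scatter). The value estimated for compound 4 is 4500 nM, with an expected range of 1500 nM to 14000 nM.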

Compound 4, concentration for 50% growth inhibition: > 100000 nM
Compound 4 ended at the assay's limit (the forecaster's own chance of this, stated with the estimate: 5%); middle value at least 22-fold (1.34 log units) away from the limit.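

At this position a small change has a large effect: in this assay the step is an at least 20-fold higher number from compound 3 to compound 4 (1.31 log units; beyond the scatter), so methyl to ethyl on the aromatic ring's substituent, a gain of 1 carbon with no ring, donor or acceptor, removes the measurable growth inhibition seen with the methyl group. Compound 4 gives > 100000 nM, which is a limit of the assay and not a number. Compound 1 and compound 4 both stand at this limit, so the step between them cannot be read: the limit of > 100000 nM in this assay, at which 2 of the 4 values shown sit.

The compounds shown leave open whether a longer chain such as propyl would also stand at the limit, or whether an amine or a hydroxyl on the saturated chain carbon would bring growth inhibition back. They also give no reason for the step from methyl to ethyl.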